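The compounds below may be only part of what the source reports. "The series", "measured", "known", "first", "only" and "open" are said of these compounds alone.

Compound 3 `Fc1cccc(-c2nn3c(Cc4ccccc4)nnc3s2)c1` gives 33% in an assay for inhibition of histone-lysine N-methyltransferase, H3 lysine-79 specific (Homo sapiens), with stated times of 15 min and 120 min, tested at 50 uM (on this read-out lower numbers stand for less inhibition and higher numbers for more inhibition at the one concentration tested (going by the name of the read-out)), the lowest of the three numbers recorded there. Compound 1 `Cc1ccc(OCc2nn3c(Cn4nnc5ccccc54)nnc3s2)cc1` gives 52% and compound 2 `Cc1cccc(OCc2nn3c(Cn4nnc5ccccc54)nnc3s2)c1` gives 50%, both beyond the scatter above compound 3. For the measured compounds named here, the one measured step, a number 2 percentage points lower from compound 1 to compound 2 (within the scatter), concerns the group on an oxygen on a saturated carbon and so has no direct bearing on compound 4 `CCc1nnc2sc(-c3cccc(F)c3)nn12`, which differs from compound 3 by methyl in place of phenyl on a saturated chain carbon bound to an aromatic carbon. Going by the values given here, no measured pair shows what removing a ring at this place does. With nothing to build on, a change within the scatter is expected, perhaps leaning lower, so compound 4 is estimated at 28% (from 10% to 45%), with the expected step being a number 5 percentage points lower from compound 3 to compound 4 (within the scatter).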

Compound 4, a percentage reported as inhibition, at one concentration (the size of the read-out at that concentration, not a potency): 13%
The estimate for compound 4 lay 15 percentage points above the measured number; low and high end bracket the measured number.
By their numbers in this assay, from the lowest: compound 4; then compound 3; then compounds 2 and 1 (each within the scatter of the next).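

In this assay, for the compounds shown here, the first measured change at this place, on a saturated chain carbon bound to an aromatic carbon, is not neutral: methyl in place of phenyl comes with a number 20 percentage points lower from compound 3 to compound 4 (beyond the scatter). Losing the phenyl therefore costs inhibition, so this place is sensitive to the change from benzyl to ethyl. Nothing measured explains the loss. Going by these compounds, it remains open whether the aromatic ring itself matters or whether a longer chain, such as propyl, or a saturated cyclohexyl ring would restore the inhibition seen with compound 3.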